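A bromophenyl group on the ring nitrogen of compound 2

A few compounds are considered here, and "the series" means these few. Any claim that something is new, unique, unknown or untested is made for them only; others in the source may bear on it.

Measured compounds:
compound 1, `N#CC1=C(N)OC2=C(CCC/C2=C\c2ccccc2)C1c1ccccc1`, 0.19%
compound 2, `COc1ccc(OC)c(/C=C2\CCCC3C2=NNC3c2cc(OC)ccc2OC)c1`, 25.6%

Of the compounds shown here, two have been measured in a functional assay for inhibition, tested at 1 mg/mL; on this read-out lower numbers stand for less inhibition and higher numbers for more inhibition at the one concentration tested (going by the name of the read-out). Compound 1, `N#CC1=C(N)OC2=C(CCC/C2=C\c2ccccc2)C1c1ccccc1`, gives 0.19% in this assay. Compound 2, `COc1ccc(OC)c(/C=C2\CCCC3C2=NNC3c2cc(OC)ccc2OC)c1`, gives 25.6% in this assay, and it stands highest of the two numbers; its nearest neighbour is compound 1, whose value lies lower by a gap that is beyond the usual scatter. Within the data shown here, the two compounds differ in many places at once, so no single step between them can be read from their values.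

Compound 3, `COc1ccc(OC)c(/C=C2\CCCC3C2=NN(c2ccc(Br)cc2)C3c2cc(OC)ccc2OC)c1`, has not been measured. It differs from compound 2 in one place: 4-bromophenyl in place of hydrogen on an amine nitrogen in a ring. Among the measured compounds shown here, no measured pair shows the effect of such a change on this read-out, so the expectation rests on compound 2 alone. Compound 3 is expected to give 30% in this assay, within a range from 8% to 55%. The step of a number 4.4 percentage points higher from compound 2 to compound 3 (within the scatter) is thus estimated to be small, close to the scatter of repeated measurements, with its direction uncertain.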

Compound 3, a percentage reported as inhibition, at one concentration (the size of the read-out at that concentration, not a potency): 0.77%
Compound 3: middle estimate off by 29.2 percentage points, on the high side; the measured number lies below the stated range.
By their numbers in this assay, from the lowest: compounds 1 and 3 (each within the scatter of the next); then compound 2.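

Placing 4-bromophenyl in place of hydrogen on the amine nitrogen in a ring gives a number 24.8 percentage points lower from compound 2 to compound 3 (beyond the scatter) in this assay, the first change at a single place that can be read in this series. It shows that the inhibition seen at the one concentration tested depends on what stands on this ring nitrogen, and that this position does not accept the 4-bromophenyl group without a clear drop in the read-out. Nothing measured here bears on why the read-out falls with this change.

The compounds shown leave open whether the drop belongs to the six-membered aromatic ring, to the bromine on it, or to any group at all on this nitrogen, since hydrogen and 4-bromophenyl are the only two groups seen there. A plain phenyl group would separate the ring from the bromine, while a methyl or an acetyl group on the same nitrogen would show whether a much smaller group brings the same drop.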